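A few compounds are considered here, and "the series" means these few. Any claim that something is new, unique, unknown or untested is made for them only; others in the source may bear on it.

Measured so far in this series:
Compound 1, `CNc1nc(O)c(Br)c(-c2ccccc2)n1`: 78%
Compound 2, `Cn1c(-c2ccccc2)cc(=O)[nH]c1=O`: 47%

Both compounds were tested in a functional assay on the whole organism for inhibition, with Rattus norvegicus as the target, at a dose of 50 mg/kg by the oral route; on this read-out lower numbers stand for a weaker effect and higher numbers for a stronger effect at the one dose given. Compound 1 `CNc1nc(O)c(Br)c(-c2ccccc2)n1` gives 78%, while compound 2 `Cn1c(-c2ccccc2)cc(=O)[nH]c1=O` gives 47%. Compound 2 therefore stands lowest of the two numbers; its nearest neighbour, compound 1, lies higher by a gap that is beyond the usual scatter of this read-out. The two compounds differ in more than one place, so nothing can be drawn from that gap about any single change.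

Compound 3 `Cn1c(-c2ccccc2)c(I)c(=O)[nH]c1=O` has not yet been measured. It is built on the core of compound 2 and differs from it by iodo in place of hydrogen on an aromatic carbon. Going by the values given here, no measured pair shows this change on its own, so its effect is not known from the data. Compound 3 is nevertheless expected to run a little higher than compound 2, an expected step of a number 13 percentage points higher from compound 2 to compound 3 (beyond the scatter) in this assay, modest and near the edge of the scatter. The estimate for compound 3 is 60%, with a range from 35% to 85%.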

Compound 3, a percentage reported as inhibition, in the whole organism at one dose (the size of the read-out at that dose, not a potency): 44%
Compound 3: the middle estimate sits 16 percentage points above what was measured; the range from low to high includes it.
By their numbers in this assay, from the lowest: compounds 3 and 2 (each within the scatter of the next); then compound 1.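

In this assay, going by these compounds alone, iodo in place of hydrogen on an aromatic carbon gives a number 3 percentage points lower from compound 2 to compound 3 (within the scatter), and this is the first change that can be read on its own. The position, ortho to a group of 6 heavy atoms and ortho to a group of 1 heavy atom, can therefore carry iodo with no difference from hydrogen beyond the scatter at the one dose given. No measurement at hand bears on the reason for this result.

Going by these compounds, whether chloro, an amine or a carboxylic acid on this same carbon would give a read-out that differs from hydrogen remains open. A single pair carries this change, so the compounds shown also leave open whether iodo would behave in the same way on another core.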